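Cytotoxicity notes: allyl to 2-cyanoethenyl

The source may hold more compounds than are shown below. What is called first, only, known or untested is meant among the compounds shown, and "the series" means these compounds.

Measured compounds:
- compound 1 `Cc1cc(/C=C/C#N)cc(C)c1Oc1ccc([N+](=O)[O-])c(Nc2ccc(C#N)cc2)n1`: > 48600 nM (a limit)
- compound 2 `Cc1cc(/C=C/C#N)cc(C)c1Oc1cc(Nc2ccc(C#N)cc2)c([N+](=O)[O-])cc1[N+](=O)[O-]`: > 43900 nM (a limit)
- compound 3 `C=CCc1cc(C)c(Oc2ccc(N)c(Nc3ccc(C#N)cc3)n2)c(C)c1`: 8460 nM

Among the measured compounds shown here, in an ADME assay on TZM cells (Homo sapiens) for cytotoxicity, read by XTT assay, with a stated time of 4 days (on this read-out higher numbers stand for lower toxicity in this test and lower numbers for higher toxicity in this test), compound 3 gives 8460 nM, the only actual number in the set. The other two values are limits, not numbers.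

Compound 4 `Cc1cc(/C=C/C#N)cc(C)c1Oc1ccc(N)c(Nc2ccc(C#N)cc2)n1` has 2-cyanoethenyl in place of allyl on an aromatic carbon of compound 3: 2-cyanoethenyl in place of allyl on an aromatic carbon.

For the measured compounds named here, no measured step isolates this change. Compound 1, which also carries 2-cyanoethenyl, has the limit > 48600 nM. Compound 2, also carrying it, has the limit > 43900 nM. A moderate step toward a higher number in this assay is therefore expected, meaning lower toxicity in this test. The estimated step is a 1.9-fold higher number from compound 3 to compound 4 (0.28 log units; within the scatter). For compound 4 the estimated value is 16000 nM, with an expected range of 6000 nM to 45000 nM.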

Compound 4, half-maximal cytotoxic concentration: 9750 nM
Estimate against measurement, compound 4: 1.6-fold (0.22 log units) above; the measured number falls inside the stated range.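

Exchanging allyl for 2-cyanoethenyl on this aromatic carbon gives a 1.2-fold higher number from compound 3 to compound 4 (0.06 log units; within the scatter) in this assay, so with the amino group present this change does not move the read-out beyond the scatter. With 2-cyanoethenyl held fixed, amino in place of nitro gives an at least 4.9-fold lower number from compound 1 to compound 4 (0.69 log units; beyond the scatter), so that exchange, not the one at this position, accounts for the larger difference. Compound 1 has a limit, not a number: the limit of > 48600 nM in this assay, at which 1 of the 4 values shown sits.

As far as these compounds go, a propyl chain or a carboxylic acid at this position remains open, as does the allyl group alongside nitro.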